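Moving the Hydroxyl Around a Phenyl Ring

The source may hold more compounds than are shown below. What is called first, only, known or untested is meant among the compounds shown, and "the series" means these compounds.

Among the measured compounds shown here, compound 2 `COc1cc(/C=C/C(=O)C2=C(/C=C/c3ccc(O)c(OC)c3)NC(=O)NC2c2ccccc2O)ccc1O` gives 81% in a functional assay, with a stated time of 20 min, tested at 20 uM (on this read-out lower numbers stand for a weaker effect and higher numbers for a stronger effect at the one concentration tested), the higher of the two numbers measured so far, while compound 1 `COc1cc(/C=C/C(=O)C2=C(/C=C/c3ccc(O)c(OC)c3)NC(=O)NC2c2ccc(C)cc2)ccc1O` gives 38.2%. Compound 3 `COc1cc(/C=C/C(=O)C2=C(/C=C/c3ccc(O)c(OC)c3)NC(=O)NC2c2ccc(O)cc2)ccc1O` differs from compound 2 in one place: 4-hydroxyphenyl in place of 2-hydroxyphenyl on a saturated ring carbon. For the measured compounds named here, the only measured step, a number 42.8 percentage points higher from compound 1 to compound 2 (beyond the scatter), concerns a different exchange on the same saturated ring carbon and bears only loosely on this one. Because a number 42.8 percentage points higher from compound 1 to compound 2 (beyond the scatter) was large, that position clearly responds to what sits there, and a moderate fall in this assay is expected, a number 21 percentage points lower from compound 2 to compound 3 (beyond the scatter), with wide uncertainty. Compound 3 is therefore estimated at 60%, between 35% and 85%.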

Compound 3, a percentage reported as activity, at one concentration (the size of the read-out at that concentration, not a potency): 84.6%
Compound 3: the middle estimate sits 24.6 percentage points below what was measured; the measured number falls inside the stated range.
By their numbers in this assay, from the lowest: compound 1; then compounds 2 and 3 (each within the scatter of the next).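

In this assay, the choice between 2-hydroxyphenyl and 4-hydroxyphenyl on the saturated ring carbon makes no difference that stands out from the scatter (a number 3.6 percentage points higher from compound 2 to compound 3 (within the scatter)). The direct exchange of hydroxy for methyl on an aromatic carbon, with the group held at the same place, gives a large change (a number 46.4 percentage points higher from compound 1 to compound 3 (beyond the scatter)), so at this position the identity of that group counts for far more than the two hydroxyl placements compared. Nothing available explains why. Still open, as far as these compounds go, is whether the hydroxy itself is needed, or whether an amine or a carboxylic acid in its place would give a similar number.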